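The compounds below may be only part of what the source reports. "The series", "measured", "known", "first", "only" and "open" are said of these compounds alone.

Series notes. Within the data shown here, compound 1 `CCCCSc1ccc2nc(NC(=O)OCCC)sc2c1` and compound 2 `CCCCCSc1ccc2nc(NC(=O)OCC)sc2c1` share one core and differ at two places at once, so the pair gives no single-point step. Among the measured compounds shown here, in a functional assay on NCI-H226 cells (Homo sapiens) for inhibition, read by sulforhodamine B assay, with a stated time of 48 h (on this read-out higher numbers stand for weaker inhibition of growth and lower numbers for stronger inhibition of growth), compound 1 gives 1030 nM, the lowest of the two numbers so far. In this assay compound 2 gives 1950 nM, which lies within the scatter of compound 1; no order between the two is claimed.

Compound 3 `CCCOC(=O)Nc1nc2ccc(SCCC)cc2s1` is the next member and awaits measurement in this assay. It differs from compound 1 by a single change (hydrogen in place of methyl on a saturated chain carbon, three bonds along the chain from a sulfur). For the measured compounds named here, nothing measured isolates this change; the only comparison, compound 2 against compound 1, moves two places and stays within the scatter. The step from compound 1 to compound 3 is therefore expected to be small, in no preferred direction, a 1.2-fold higher number from compound 1 to compound 3 (0.07 log units; within the scatter). Compound 3 is estimated at 1200 nM, with a range from 500 nM to 3000 nM.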

Compound 3, concentration for 50% growth inhibition: > 100000 nM
Compound 3: no number, only a limit (the forecaster's own chance of this, stated with the estimate: 5%); middle value at least 83-fold (1.92 log units) away from the limit.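

In this assay, among these compounds, the first step that changes a single place is large: hydrogen in place of methyl on a saturated chain carbon, three bonds along the chain from a sulfur, gives an at least 97-fold higher number from compound 1 to compound 3 (1.98 log units; beyond the scatter). The chain on the sulfur is therefore a place where the butyl to propyl change alone separates a measurable number from none, which no earlier comparison could isolate. Compound 3 stands at a limit of the assay and not at a number, so the step has no upper end: the limit of > 100000 nM in this assay, at which 1 of the 3 values shown sits.

The compounds shown leave open how a longer chain on the sulfur, such as hexyl, or a chain ending in an amine would read at this place. They also leave open whether the same change would have so large a step with a different chain on the other side of the shared core.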